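Thiosemicarbazones of a terpenoid amine: cytotoxicity notes

This account rests on a few compounds, and the source may have more. Where it says the series, first, only, none or still open, it means among the compounds named here.

Measured compounds in a functional assay on NCI-H460 cells (Homo sapiens) for cytotoxicity, read by sulforhodamine B assay; on this read-out higher numbers stand for lower toxicity in this test and lower numbers for higher toxicity in this test:
Compound 1 `CC1=CC[C@@H]([C@@](C)(O)CCCC(C)(C)NC=S)CC1`. Compound 1 gives > 100000 nM, a limit of the assay.
Compound 2 `COc1ccc(/C=N\NC(=S)NC(C)(C)CCC[C@](C)(O)[C@@H]2CC=C(C)CC2)cc1`. Compound 2 gives > 100000 nM, a limit of the assay.
Compound 3 `CC1=CC[C@@H]([C@@](C)(O)CCCC(C)(C)NC(=S)N/N=C\c2ccc(O)cc2)CC1`. Compound 3 gives > 100000 nM, a limit of the assay.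

Compound 2 stands at the limit of this assay, and the two other values shown are limits as well, so no number places it relative to anything else in the series. Among the compounds with values here, the only step between measured compounds that differ in one place, a step that the two limits leave unreadable from compound 2 to compound 3, is not readable in size, since both ends are limits; its change is hydrogen in place of methyl on an oxygen on an aromatic ring. the limit of > 100000 nM in this assay, at which 3 of the 3 values shown sit, is the single piece of evidence, and it says that none of the three measured compounds reaches a measurable concentration.

Compound 4 `CC1=CC[C@@H]([C@@](C)(O)CCCC(C)(C)NC(=S)N/N=C\c2ccccc2[N+](=O)[O-])CC1` differs from compound 2 by 2-nitrophenyl in place of 4-methoxyphenyl on a carbon with a double bond to nitrogen. Within the data shown here, no measured step bears on an aromatic substituent of this kind, and the step from compound 2 to compound 3 gives no size to compare against. The expectation for compound 4 therefore rests only on the three limits: compound 4 is expected to give 150000 nM in this assay, within 50000 nM to 500000 nM. The step from compound 2 to compound 4 is estimated as a step that the limit leaves unreadable from compound 2 to compound 4, with a limit rather than a number the most likely outcome.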

Compound 4, concentration lethal to 50% of the cells: > 100000 nM
Compound 4 gave a limit, no number; the forecaster's own chance of this, stated with the estimate: 85%; the middle value lies beyond the limit too.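

In this assay compound 4 gives > 100000 nM, which is a limit of the assay and not a number. The steps from compound 2 and compound 3 to compound 4 therefore cannot be read: the limit of > 100000 nM in this assay, at which 4 of the 4 values shown sit.

The compounds shown leave open whether 2-nitrophenyl, 4-methoxyphenyl and 4-hydroxyphenyl differ at all in this assay.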